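The compounds below may be only part of what the source reports. "The series", "measured", "known", "first", "only" and "open" are said of these compounds alone.

In a functional assay on HSC-4 cells (Homo sapiens) for cytotoxicity, with a stated time of 24 h (on this read-out higher numbers stand for lower toxicity in this test and lower numbers for higher toxicity in this test), compound 1 `O=C1/C(=C/c2ccc(Cl)cc2)CCC/C1=C\c1ccc([N+](=O)[O-])cc1` gives 2700 nM as its reading. Compound 2 `CN(C)c1ccc(/C=C2\CCC/C(=C\c3ccc([N+](=O)[O-])cc3)C2=O)cc1` gives > 400000 nM as a limit of the assay and not as a number. Compound 2 therefore has no exact place on the scale. Compound 3 `COc1ccc(/C=C2\CCC/C(=C\c3ccc([N+](=O)[O-])cc3)C2=O)cc1` carries methoxy in place of dimethylamino on an aromatic carbon, and methoxy in place of dimethylamino on an aromatic carbon sets out that change. Among the measured compounds shown here, one measured step bears on this swap, since it also involves dimethylamino: an at least 140-fold higher number from compound 1 to compound 2 (2.17 log units; beyond the scatter) is the large step seen with dimethylamino in place of chloro. Removing dimethylamino from compound 2 is thus expected to give a clear move toward lower numbers, meaning higher toxicity, although methoxy itself has not been measured here. The expected size is an estimated at least 20-fold lower number from compound 2 to compound 3 (1.30 log units; beyond the scatter) in this assay for this swap. Compound 3 is estimated at 20000 nM within an expected range of 4000 nM to 100000 nM in this assay overall.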

Compound 3, half-maximal cytotoxic concentration: > 400000 nM
Compound 3 gave a limit, no number (the forecaster's own chance of this, stated with the estimate: 10%); middle value at least 20-fold (1.30 log units) away from the limit.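

In this assay, methoxy in place of chloro on the aromatic carbon gives an at least 140-fold higher number from compound 1 to compound 3 (2.17 log units; beyond the scatter), a size that rests on a limit of the assay for compound 3 and not on an exact number. The large move toward lower toxicity in this test is therefore not tied to dimethylamino alone, since two different groups at this place, dimethylamino in compound 2 and methoxy in compound 3, both leave the reading of compound 1 far behind. The step between these two cannot be read, because both stop at the same limit: the limit of > 400000 nM in this assay, at which 2 of the 3 values shown sit.

Going by these compounds, how far apart compound 2 and compound 3 truly lie stays unknown. On these data alone, it also stays open whether a fluoro, bromo or methyl group at this place would read close to chloro or would reach the same limit.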